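The compounds below may be only part of what the source reports. "The series", "measured", "known", "first", "only" and "open" are said of these compounds alone.

Measured compounds in an ADME assay on 2209-23 cells (Homo sapiens) for cytotoxicity, read by WST assay and thymidine incorporation; on this read-out lower numbers stand for higher toxicity in this test and higher numbers for lower toxicity in this test:

Compound 1 `Cc1cc(CN2C(=O)C(C3=CS(=O)(=O)c4cc(NS(C)(=O)=O)ccc4N3)=C(O)[C@@H]2C(C)(C)C)ccc1F` gives > 50000 nM in this assay, which is a limit of the assay and not a number.
Compound 2 `CC(C)(C)[C@H]1C(O)=C(C2=C(Cl)S(=O)(=O)c3cc(NS(C)(=O)=O)ccc3N2)C(=O)N1Cc1ccc(F)cc1` gives > 50000 nM in this assay, again a limit of the assay rather than a number.

For the measured compounds named here, compound 1 therefore stands at the assay limit, and the only further value shown is also a limit: the limit of > 50000 nM in this assay, at which 2 of the 2 values shown sit. Going by the values given here, no step between measured compounds that differ in one place is available, so nothing is known from these two compounds about how a single change shifts the read-out.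

Compound 3 `CC(C)(C)[C@H]1C(O)=C(C2=CS(=O)(=O)c3cc(NS(C)(=O)=O)ccc3N2)C(=O)N1Cc1ccc(F)c(Cl)c1` is not yet measured in this assay. It differs from compound 1 by chloro in place of methyl on an aromatic carbon.

For compound 3 the step from compound 1 is expected to be none beyond the scatter, a step that the limit leaves unreadable from compound 1 to compound 3, since both measured values sit at the limit. Compound 3 is estimated at 60000 nM, with a range from 30000 nM to 200000 nM, and most likely the assay reports only a limit again.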

Compound 3, half-maximal cytotoxic concentration: > 50000 nM
Compound 3 ended at the assay's limit; the forecaster's own chance of this, stated with the estimate: 85%; the middle value is on the limit's open side.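

No step can be read from compound 1 to compound 3 in this assay, since both results are limits of the assay and not numbers: the limit of > 50000 nM in this assay, at which 3 of the 3 values shown sit.

It remains open at what concentration any of these compounds reaches the half-maximal cytotoxic effect in this assay, and whether chloro in place of methyl shifts that concentration.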